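Halogen swap on the shared core: from compound 2 to compound 3

The compounds below may be only part of what the source reports. "The series", "measured", "known", "first", "only" and "open" are said of these compounds alone.

Measured compounds:
compound 1, `Nc1scc(-c2ccccc2)c1C(=O)c1ccc(Cl)cc1`: 51%
compound 2, `Nc1scc(-c2cccc(Cl)c2)c1C(=O)c1ccc(Cl)cc1`: 58%

In a functional assay on CHO cells for agonist activity at adenosine receptor A1 (Homo sapiens), read by fluorescence and ERK phosphorylation, with stated times of 30 min and 1.5 h, tested at 3 uM (a lower number here means a weaker effect, a higher number a stronger effect of the compound at the concentration tested), compound 1 gives 51%. In the same assay compound 2 gives 58%. For the measured compounds named here, the only step between measured compounds is a number 7 percentage points higher from compound 1 to compound 2 (within the scatter), a chloro in place of hydrogen on an aromatic carbon. The two numbers therefore stand within the scatter of each other, and compound 2 is not set apart from compound 1 on the numbers shown; it simply serves as the starting point for the next change.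

Compound 3, `Nc1scc(-c2ccc(I)cc2)c1C(=O)c1ccc(Cl)cc1`, has not yet been measured in this assay. It differs from compound 2 by 4-iodophenyl in place of 3-chlorophenyl on an aromatic carbon. Going by the values given here, no measured step shows this kind of change: the one step in hand, from compound 1 to compound 2, adds a chloro where hydrogen stood and stays within the scatter. There is thus no measured ground for expecting a move in this assay beyond the scatter in either direction, and the number for compound 3 is expected to sit near that of compound 2, with a number 3 percentage points lower from compound 2 to compound 3 (within the scatter) as the estimated step. Compound 3 is estimated at 55%, within a range from 35% to 75%.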

Compound 3, a percentage reported as activity, at one concentration (the size of the read-out at that concentration, not a potency): 54%
The estimate for compound 3 lay 1 percentage points above the measured number; the measured number falls inside the stated range.
By their numbers in this assay, from the lowest: compounds 1, 3 and 2 (each within the scatter of the next).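

In this assay, the change from 3-chlorophenyl to 4-iodophenyl on this aromatic carbon of the five-membered aromatic ring with 1 sulfur gives a number 4 percentage points lower from compound 2 to compound 3 (within the scatter), and iodo in place of hydrogen gives a number 3 percentage points higher from compound 1 to compound 3 (within the scatter). All three compounds now stand within the scatter of one another, so on these numbers neither halogen sets its compound apart from the unsubstituted phenyl of compound 1, even though the halogen and its place on the phenyl ring differ between compound 2 and compound 3. No information is at hand to explain this outcome.

Because the halogen and its place on the phenyl ring change together from compound 2 to compound 3, these compounds cannot separate the two changes, and the read-out at one concentration says nothing about potency. From the compounds shown here alone, it also remains open whether a group of another kind on this phenyl ring, such as an amine or a carboxylic acid, would move the number beyond the scatter.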